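This account rests on a few compounds, and the source may have more. Where it says the series, first, only, none or still open, it means among the compounds named here.

Measured so far:
compound 1 `Cc1ccc(NC(=O)c2cc3ccccc3oc2=O)cc1`, 19500 nM
compound 2 `CC(C)c1ccc(NC(=O)c2cc3ccccc3oc2=O)cc1`, 15100 nM
compound 3 `CSc1ccc(NC(=O)c2cc3ccccc3oc2=O)cc1`, 14800 nM

All three compounds share one core and differ only in the group carried on the outer aromatic ring. In an in vitro assay on BTI-TN-5B1-4 cells for inhibition of Amine oxidase [flavin-containing] A (Homo sapiens), read by fluorescence (on this read-out higher numbers stand for weaker inhibition and lower numbers for stronger inhibition), compound 3 gives the lowest of the three numbers, but its distance from compound 2 (a 1.0-fold lower number from compound 2 to compound 3 (0.01 log units; within the scatter)) and from compound 1 (a 1.3-fold lower number from compound 1 to compound 3 (0.12 log units; within the scatter)) both lie within the scatter, so the three compounds cannot be told apart on these data.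

Compound 4 `CS(=O)(=O)c1ccc(NC(=O)c2cc3ccccc3oc2=O)cc1` carries another group in the same place: methylsulfonyl in place of methylsulfanyl on an aromatic carbon. Within the data shown here, no measured step swaps these two groups. The steps that come closest are the other swaps on that ring, a 1.3-fold lower number from compound 1 to compound 2 (0.11 log units; within the scatter) and a 1.3-fold lower number from compound 1 to compound 3 (0.12 log units; within the scatter), both within the scatter. Among the measured compounds shown here, every change tried at this place so far kept the number within the scatter, and compound 4 is therefore expected to stay close to compound 3, with the step of a 1.1-fold higher number from compound 3 to compound 4 (0.03 log units; within the scatter) not expected to go beyond the scatter. Compound 4 is estimated at 16000 nM, with a range from 5000 nM to 50000 nM.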

Compound 4, half-maximal inhibitory concentration: 9330 nM
Beside the measured number, compound 4's estimate is 1.7-fold (0.23 log units) above it; low and high end bracket the measured number.
By their numbers in this assay, from the lowest: compounds 4, 3, 2 and 1 (each within the scatter of the next, the first and the last beyond it).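

Swapping in methylsulfonyl, with its two oxygens, leaves compound 4 within the scatter of its two closest neighbours: a 1.6-fold lower number from compound 3 to compound 4 (0.20 log units; within the scatter) and a 1.6-fold lower number from compound 2 to compound 4 (0.21 log units; within the scatter) cannot be read as real differences in this assay on these data. Among these compounds, the one step at this position to pass beyond the scatter is a 2.1-fold lower number from compound 1 to compound 4 (0.32 log units; beyond the scatter) and it is modest, so this place on the ring has now taken four different groups with only a small spread in the numbers. Nothing available explains that step.

From the compounds shown here alone, whether an amine or a carboxylic acid at this same place would shift the number further remains open. So does whether methylsulfonyl would give a similar number at another place on the outer ring.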